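The source may hold more compounds than are shown below. What is called first, only, known or untested is meant among the compounds shown, and "the series" means these compounds.

Measured compounds:
compound 1 `CCOC(=O)CCCOc1cccc(/C=C/c2ccc3ccccc3n2)c1`, 580 nM
compound 2 `O=C(O)CCCOc1cccc(/C=C/c2ccc3ccccc3n2)c1`, 480 nM
compound 3 `O=C(O)CCCOc1cccc(/C=C/c2ccc3ccc(Cl)cc3n2)c1`, 39 nM

In a functional assay on lung (Cavia porcellus) for binding affinity to cysteinyl leukotriene receptor (Homo sapiens) (on this read-out lower numbers stand for stronger inhibition and higher numbers for weaker inhibition), compound 2 gives 480 nM, the second highest of the three numbers. Its nearest neighbour is compound 1, with a 1.2-fold lower number from compound 1 to compound 2 (0.08 log units; within the scatter). Furthest from it is compound 3, with a 12-fold lower number from compound 2 to compound 3 (1.09 log units; beyond the scatter). Compound 4 `O=C(O)CCCOc1cccc(/C=C/c2ccc3c(Cl)cccc3n2)c1` has not yet been measured. It differs from compound 2 by chloro in place of hydrogen on an aromatic carbon. The step from compound 2 to compound 3 bears on this change, as there too chloro replaced hydrogen on an aromatic carbon, though at a different aromatic carbon of the core; that step was large and downward, so a downward step is expected here as well, but with room for a smaller one. Compound 4 is therefore expected to give 160 nM, with a range from 60 nM to 480 nM. That estimate means a step of a 3.0-fold lower number from compound 2 to compound 4 (0.48 log units; beyond the scatter).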

Compound 4, half-maximal inhibitory concentration: 1430 nM
For compound 4 the middle estimate is 8.9-fold (0.95 log units) below the measured one; the whole stated range lies below it.
By their numbers in this assay, from the lowest: compound 3; then compounds 2 and 1 (each within the scatter of the next); then compound 4.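

Chloro in place of hydrogen does not move the number in one direction across the shared core. On this aromatic carbon, ortho to a fused ring, the change gives a 3.0-fold higher number from compound 2 to compound 4 (0.47 log units; beyond the scatter) and so runs opposite to a 12-fold lower number from compound 2 to compound 3 (1.09 log units; beyond the scatter) on a different aromatic carbon. No measurement given here accounts for this reversal.

On these data alone, whether fluoro or methoxy on the same carbon would raise the number as chloro does remains open. So does whether the step from chloro would hold with a longer chain carrying the carboxylic acid.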